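Furan-2-yl to 2-hydroxyphenyl: from compound 3 to compound 4

A few compounds are considered here, and "the series" means these few. Any claim that something is new, unique, unknown or untested is made for them only; others in the source may bear on it.

Measured in a functional assay on ECa-109 cells for antiproliferative activity against ECa-109 cell line (Homo sapiens), read by MTT assay, with a stated time of 72 h; a higher number here means a weaker inhibitor, a lower number a stronger inhibitor:
- Compound 1 `C/C(=N\NC(=O)c1cccc(S(=O)(=O)N2CCOCC2)c1)c1ccccc1O`: 5450 nM
- Compound 2 `C/C(=N\NC(=O)c1cccc(S(=O)(=O)N2CCOCC2)c1)c1cc(F)ccc1O`: 3270 nM
- Compound 3 `O=C(N/N=C/c1ccco1)c1cccc(S(=O)(=O)N2CCOCC2)c1`: > 100000 nM

Compound 3 stands at the limit of > 100000 nM in this assay, at which 1 of the 3 values shown sits, and its reading is a limit, not a number. The next compound, compound 4 `O=C(N/N=C/c1ccccc1O)c1cccc(S(=O)(=O)N2CCOCC2)c1`, has 2-hydroxyphenyl in place of furan-2-yl on a carbon with a double bond to nitrogen.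

Within the data shown here, the only measured step, a 1.7-fold lower number from compound 1 to compound 2 (0.22 log units; within the scatter), is fluoro in place of hydrogen on an aromatic carbon. It stays within the scatter and does not test this exchange, so the expectation rests on the values themselves. Compound 1 also carries 2-hydroxyphenyl on such a carbon and gives 5450 nM. In this assay a large move towards a lower number is therefore expected, with an estimated step of an at least 12-fold lower number from compound 3 to compound 4 (1.09 log units; beyond the scatter). For compound 4 the estimated value is 8000 nM, with an expected range from 2000 nM to 40000 nM.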

Compound 4, half-maximal inhibitory concentration: 14400 nM
For compound 4 the middle estimate is 1.8-fold (0.26 log units) below the measured one; measured number inside the range.
By their numbers in this assay, from the lowest: compounds 2 and 1 (each within the scatter of the next); then compound 4. At a limit, above all of these: compound 3.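

In this assay, the group on the carbon with a double bond to nitrogen proves to matter: 2-hydroxyphenyl in place of furan-2-yl gives an at least 6.9-fold lower number from compound 3 to compound 4 (0.84 log units; beyond the scatter), whereas the fluoro exchange between compound 1 and compound 2 stayed within the scatter. As far as these compounds go, the true size of this step remains unknown because the reading of compound 3 is a limit, not a number: the limit of > 100000 nM in this assay, at which 1 of the 4 values shown sits. The exchange also replaces the ring and brings in the hydroxyl in a single step, so the gain cannot be assigned to either one alone.

The compounds shown leave open whether plain phenyl at this carbon would retain the gain without the hydroxyl. From the compounds shown here alone, it is also open whether methoxy or an amine could stand in for that hydroxyl.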